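Aryl swap on a piperazine: from compound 1 to compound 3

The compounds below may be only part of what the source reports. "The series", "measured", "known", "first", "only" and "open" are said of these compounds alone.

Compound 1 `CNc1ccccc1N1CCN(CCCCn2ncc(=O)n(C)c2=O)CC1` gives 450 nM in an assay for displacement of a labelled ligand from Adrenergic receptor alpha-1 (Homo sapiens); a lower number here means a stronger inhibitor, a higher number a weaker inhibitor. Compound 2 `Cn1c(=O)cnn(CCCCN2CCN(c3c(Br)cccc3C#N)CC2)c1=O` gives 450 nM, and the step of no change at the digits printed from compound 1 to compound 2 (within the scatter) shows that replacing the 2-(methylamino)phenyl with 2-bromo-6-cyanophenyl on the amine nitrogen in the ring left the value level with compound 1. Compound 3 `Cn1c(=O)cnn(CCCCN2CCN(c3cccc(O)c3)CC2)c1=O` carries the change (3-hydroxyphenyl in place of 2-(methylamino)phenyl on an amine nitrogen in a ring). Going by the values given here, the only comparable step, no change at the digits printed from compound 1 to compound 2 (within the scatter), changed nothing beyond the scatter, so the step of a 1.1-fold lower number from compound 1 to compound 3 (0.05 log units; within the scatter) is expected to be small as well. Compound 3 is therefore estimated at 400 nM, within 150 nM to 1200 nM.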

Compound 3, inhibition constant: > 10000 nM
Compound 3 ended at the assay's limit; the forecaster's own chance of this, stated with the estimate: 5%; middle value at least 25-fold (1.39 log units) from the limit.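

The position on the amine nitrogen in the ring does not accept every aryl group, which the level pair of compound 1 and compound 2 could not show. In this assay, 3-hydroxyphenyl gives an at least 22-fold higher number from compound 1 to compound 3 (1.34 log units; beyond the scatter) and an at least 22-fold higher number from compound 2 to compound 3 (1.34 log units; beyond the scatter). Compound 3 gives > 10000 nM, which is a limit of the assay and not a number, so both steps fix only a minimum size: the limit of > 10000 nM in this assay, at which 1 of the 3 values shown sits.

The compounds shown leave open whether this large step belongs to the hydroxyl itself. A methoxy group or an amine on the same phenyl would bear on that.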